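The compounds below may be only part of what the source reports. "The series", "measured", "known", "first", "only" and "open" are said of these compounds alone.

Compound 1 `CC(C)C(c1ncc[nH]1)c1ccc(-c2ccc3cccc(F)c3c2)[nH]c1=O` carries a 1H-imidazol-2-yl group on a saturated chain carbon bound to an aromatic carbon and a saturated chain carbon. In an ADME assay on microsomes from liver (Rattus norvegicus) for metabolic stability (on this read-out higher numbers stand for a longer-lived compound and lower numbers for a shorter-lived compound), compound 1 gives < 0.0667 h, which is a limit of the assay. Compound 2 `CC(C)C(Cc1ncc[nH]1)c1ccc(-c2ccc3cccc(F)c3c2)[nH]c1=O` has (1H-imidazol-2-yl)methyl in place of that group. In this assay compound 2 gives < 0.0667 h, again a limit. Compound 3 `CC(C)C(c1ccc(-c2ccc3cccc(F)c3c2)[nH]c1=O)N1CCCCS1(=O)=O` bears instead a group of 8 heavy atoms (4 carbon, 1 nitrogen, 2 oxygen, 1 sulfur; one six-membered non-aromatic ring with 2 hetero atoms), and in this assay compound 3 gives 0.07 h. Compound 1 thus stands at the limit of < 0.0667 h in this assay, at which 2 of the 3 values shown sit, the short-lived end of what has been measured; the step of an at least 1.0-fold higher number from compound 1 to compound 3 (0.02 log units; that floor lies within the scatter) stays within the scatter, and the step that the two limits leave unreadable from compound 1 to compound 2.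

Compound 4 `Cc1c[nH]c(C(c2ccc(-c3ccc4cccc(F)c4c3)[nH]c2=O)C(C)C)n1` differs from compound 1 by methyl in place of hydrogen on an aromatic carbon. Within the data shown here, no measured step alters the five-membered aromatic ring with 2 nitrogen in this way, and no measured change in this set moved the number beyond the scatter, so for compound 4 a step that the limit leaves unreadable from compound 1 to compound 4 is expected. Compound 4 is therefore estimated at 0.06 h, with a range from 0.03 h to 0.12 h, and a limit rather than a number is the likelier report.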

Compound 4, half-life: < 0.0667 h
Compound 4: no number, only a limit; the forecaster's own chance of this, stated with the estimate: 65%; the middle value does not contradict the limit.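

In this assay compound 4 gives < 0.0667 h, which is a limit of the assay. Among these compounds, the limit now also covers a change on the five-membered aromatic ring itself, not only on the link to that ring: the limit of < 0.0667 h in this assay, at which 3 of the 4 values shown sit. The steps from compound 1 and from compound 2 to compound 4 cannot be read, with limits at both ends, and the one readable step is an at least 1.0-fold lower number from compound 3 to compound 4 (0.02 log units; that floor lies within the scatter), so the 4-methyl-1H-imidazol-2-yl group of compound 4 cannot be told apart here from the group on compound 3.

Going by these compounds, whether methyl on this aromatic carbon changes the half-life at all stays open. Also open, on these data alone, is whether a different group there, such as trifluoromethyl or a carboxylic acid, or an amine in place of the whole ring on the saturated chain carbon, would give a clearly longer half-life.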